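Sulfonyl carbamates and ureas: a hexyloxy variant of compound 2

This account rests on a few compounds, and the source may have more. Where it says the series, first, only, none or still open, it means among the compounds named here.

Of the compounds shown here, three have been tested in an assay on liver for inhibition of sterol O-acyltransferase 1 (Rattus norvegicus), using microsomes; on this read-out higher numbers stand for weaker inhibition and lower numbers for stronger inhibition. Compound 1 `CCCCN(CCCC)S(=O)(=O)N(C)C(=O)Nc1c(C(C)C)cccc1C(C)C`, the urea member, gives > 5000 nM, which is a limit of the assay rather than a number. Compound 2 `CCCCN(CCCC)S(=O)(=O)NC(=O)Oc1c(C(C)(C)C)cc(C)cc1C(C)(C)C`, the dibutylsulfamoyl carbamate, gives 3200 nM. Compound 3 `CC(C)c1cccc(C(C)C)c1OC(=O)NS(=O)(=O)Oc1c(C(C)(C)C)cccc1C(C)(C)C`, in which an aryloxy group sits on the sulfonyl sulfur, gives 50000 nM. Of the two numbers shown, compound 2 stands lowest; the gap to compound 3 is beyond the scatter, and the third value is a limit only. Among the measured compounds shown here, no pair of measured compounds differs in a single place, so no step size can be read off directly.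

Compound 4 `CCCCCCOS(=O)(=O)NC(=O)Oc1c(C(C)(C)C)cc(C)cc1C(C)(C)C` keeps the carbamate and the aryl portion of compound 2 and differs from it in one place: hexyloxy in place of dibutylamino on a sulfonyl sulfur. For the measured compounds named here, the only other compound carrying an oxygen on the sulfonyl sulfur is compound 3, whose value of 50000 nM lies well above that of compound 2, though compound 3 also carries a different aryl ester and is not a single-point comparison. On that basis the step from compound 2 to compound 4 is expected to be a loss of moderate size, a 2.2-fold higher number from compound 2 to compound 4 (0.34 log units; beyond the scatter), towards weaker inhibition. Compound 4 is therefore estimated at 7000 nM, with a range of 2000 nM to 25000 nM, and a real chance that the assay returns only a limit.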

Compound 4, half-maximal inhibitory concentration: 95000 nM
Compound 4: middle estimate off by 14-fold (1.13 log units), on the low side, outside the stated range (above it).
By their numbers in this assay, from the lowest: compound 2; then compounds 3 and 4 (each within the scatter of the next).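

In this assay, the sulfonyl sulfur proves to be a place where one change carries a large loss: hexyloxy in place of dibutylamino gives a 30-fold higher number from compound 2 to compound 4 (1.47 log units; beyond the scatter), with the carbamate and the aryl portion unchanged. Both groups are open chains with no ring and no net charge, and they differ mainly in the nitrogen of dibutylamino against the oxygen of hexyloxy, with one hydrogen-bond acceptor entering, so this position does not treat the two as interchangeable. No measured property in hand accounts for the size of this step.

Still open, going by these compounds, is whether the loss follows the oxygen on the sulfonyl sulfur or the replacement of two butyl chains by a single chain; a hexylamino group at the same place, or a dibutylamino analogue with a shorter pair of chains such as diethylamino, would begin to separate the two. On these data alone, whether the step carries over to the urea of compound 1 also stays open, its > 5000 nM being a limit and not a number.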